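This account rests on a few compounds, and the source may have more. Where it says the series, first, only, none or still open, it means among the compounds named here.

Working notes on the series. Among the measured compounds shown here, in a functional assay on HT-1080 cells (Homo sapiens) for antiproliferative activity, read by MTT assay, with a stated time of 72 h (on this read-out higher numbers stand for weaker inhibition and lower numbers for stronger inhibition), compound 1 (`CCOC(=O)c1cc(-c2ccc(OC)cc2)c(-c2cc(OC)c(OC)c(OC)c2)s1`) gives 7630 nM, the lower of the two numbers measured so far. Compound 2 (`CCOC(=O)c1cc(-c2ccc(OC)c([N+](=O)[O-])c2)c(-c2cc(OC)c(OC)c(OC)c2)s1`) gives 26100 nM. Compound 3 (`COc1ccc(-c2cc(C(=O)O)sc2-c2cc(OC)c(OC)c(OC)c2)cc1`) has not yet been measured. Its difference from compound 1 is hydrogen in place of ethyl on an oxygen next to a carbonyl group, which reads as ethoxycarbonyl to carboxy. For the measured compounds named here, only one measured step is available, a 3.4-fold higher number from compound 1 to compound 2 (0.53 log units; beyond the scatter). That step is nitro in place of hydrogen on an aromatic carbon, a different place from the change in compound 3, so it serves only as a gauge of how far one change has moved the number in this series. Going by the values given here, no measured compound tests the ester position directly, so the direction rests on judgement alone. A step of similar or somewhat larger size is expected in this assay, towards a higher number and so weaker inhibition. The estimated step is a 3.3-fold higher number from compound 1 to compound 3 (0.52 log units; beyond the scatter). For compound 3 the expected value is 25000 nM, with an estimated range of 9000 nM to 70000 nM.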

Compound 3, half-maximal inhibitory concentration: 5810 nM
For compound 3 the middle estimate is 4.3-fold (0.63 log units) above the measured one, outside the stated range (below it).
By their numbers in this assay, from the lowest: compounds 3 and 1 (each within the scatter of the next); then compound 2.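

Working notes, continued. In this assay, hydrogen in place of ethyl on an oxygen next to a carbonyl group, read as ethoxycarbonyl to carboxy, gives a 1.3-fold lower number from compound 1 to compound 3 (0.12 log units; within the scatter) and so leaves the two numbers indistinguishable on this read-out. Among the compounds shown here, this is the first measured reading at this position, and it differs in kind from the only earlier step, a 3.4-fold higher number from compound 1 to compound 2 (0.53 log units; beyond the scatter) at an aromatic carbon, since the exchange of the ethyl for a hydrogen stays within the scatter. No measurement is at hand that would explain this result, so the notes record only the size of the step.

The compounds shown leave open whether an amide or a hydroxymethyl group in place of ethoxycarbonyl would also stay within the scatter of compound 1, and whether a longer chain such as butyl in place of ethyl on the same oxygen would do so. They also leave open whether nitro in place of hydrogen on an aromatic carbon would give a step of similar size when carboxy stands in place of ethoxycarbonyl.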